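The source may hold more compounds than are shown below. What is called first, only, known or untested is meant among the compounds shown, and "the series" means these compounds.

For the measured compounds named here, compound 1, `CN1C[C@@H](c2ccc(F)cc2)[C@@]2(Cc3ccccc3C2=O)[C@@]12C(=O)Nc1ccccc12`, and compound 2, `CN1C(=O)[C@@]2(c3ccccc31)N(C)C[C@@H](c1ccc(Cl)cc1)[C@@]21Cc2ccccc2C1=O`, are the two members that have a number so far. In a functional assay on the whole organism (strain Wister albino) for inhibition, with Rattus norvegicus as the target, read by paw edema, with stated times of 1 h and 3 h, at a dose of 50 mg/kg by the intraperitoneal route (a lower number here means less inhibition, a higher number more inhibition at the dose given (going by the name of the read-out)), compound 1 gives 21.1%, and in this assay compound 2 gives 9.4%. Compound 1 thus stands highest of the two values, with compound 2 the nearer one at a distance that lies beyond the usual scatter of repeated measurements. Going by the values given here, compound 1 and compound 2 differ in more than one place, so no single step between them can be read off.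

The next compound, compound 3, `CN1C[C@@H](c2ccco2)[C@@]2(Cc3ccccc3C2=O)[C@@]12C(=O)Nc1ccccc12`, is derived from compound 1 by one change: furan-2-yl in place of 4-fluorophenyl on a saturated ring carbon.

Among the compounds with values here, no step of this kind has been measured, so the expectation rests on compound 1 alone. A modest downward step from compound 1 to compound 3 is expected, of a size that would not clearly exceed the scatter: a number 6.1 percentage points lower from compound 1 to compound 3 (within the scatter). For compound 3 in this assay the estimate is 15%, with a range from 3% to 30%.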

Compound 3, a percentage reported as inhibition, in the whole organism at one dose (the size of the read-out at that dose, not a potency): 38.8%
Compound 3: the middle estimate sits 23.8 percentage points below what was measured; the measured number lies above the stated range.
By their numbers in this assay, from the lowest: compound 2; then compound 1; then compound 3.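

In this assay, for the compounds shown here, the saturated ring carbon of the five-membered non-aromatic ring with 1 nitrogen proves sensitive to the group it carries: furan-2-yl in place of 4-fluorophenyl gives a number 17.7 percentage points higher from compound 1 to compound 3 (beyond the scatter), the first step that can be read. On this core, 4-fluorophenyl is therefore not needed for inhibition at the dose given, and a five-membered aromatic ring with 1 hetero atom and fewer heavy atoms gives the higher read-out. No measurement bears on why the step occurs, so the differences counted between the two groups, namely ring size, the ring oxygen and the hydrogen-bond acceptor, remain unassigned.

Going by these compounds alone, the single exchange cannot separate these differences, and thiophen-2-yl or unsubstituted phenyl at the same carbon would help show whether the ring oxygen or the smaller ring goes with the higher number. On these data alone, it also remains open whether a basic amine such as a dimethylaminomethyl group is accepted on the ring at this carbon, and whether furan-2-yl keeps the same direction where a methyl group replaces the amide hydrogen, as it does in compound 2.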